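The source may report more compounds than this note shows. Statements on the series, on what has been measured and on what is new or still open speak of the compounds shown alone.

In a functional assay on KB cells (Homo sapiens) for cytotoxicity (a higher number here means that more compound is needed for the effect, a lower number that less compound is needed), compound 1 `Oc1ccc2nc(-c3ccccc3)cc(O)c2c1` gives 0.41 ug/mL. Compound 3 `Oc1cc(-c2ccccc2)nc2cc(F)ccc12` reaches (the limit of < 0.1 ug/mL in this assay, at which 1 of the 3 values shown sits), so its result is a limit and not a number: < 0.1 ug/mL. Compound 2 `CC(C)COc1cc(-c2ccccc2)nc2ccccc12` stands at the opposite end, at the limit of > 4 ug/mL in this assay, at which 1 of the 3 values shown sits, again a limit rather than a number: > 4 ug/mL. Among the three results shown, compound 2 is thus the one sitting at the high limit of this assay. Compound 4 `c1ccc(COc2cc(-c3ccccc3)nc3ccccc23)cc1` differs from compound 2 by phenyl in place of isopropyl on a saturated chain carbon bound to an oxygen on an aromatic ring. Within the data shown here, no measured pair shows a change of this kind, so its size is open. Compound 4 is expected to remain near the same limit, a step from compound 2 to compound 4 of a step that the limit leaves unreadable from compound 2 to compound 4. For compound 4 the estimate is 6 ug/mL, with a range from 2 ug/mL to 20 ug/mL.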

Compound 4, half-maximal effective concentration: 1.6 ug/mL
Compound 4: middle estimate off by 3.8-fold (0.57 log units), on the high side, outside the stated range (below it).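

In this assay, replacing isobutoxy with benzyloxy gives an at least 2.5-fold lower number from compound 2 to compound 4 (0.39 log units; beyond the scatter). Among these compounds, this is the first sign that the group on this oxygen can shift the result, as compound 4 gives a readable number. The step is only a minimum because the result for compound 2 is a limit: the limit of > 4 ug/mL in this assay, at which 1 of the 4 values shown sits.

This single pair cannot separate the effect of the aromatic ring from that of the larger group. Going by these compounds, how a longer chain or an amine at this place would compare remains open.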